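A few compounds are considered here, and "the series" means these few. Any claim that something is new, unique, unknown or untested is made for them only; others in the source may bear on it.

In an ADME assay on microsomes from liver (Mus musculus, strain CD-1) for metabolic stability, read by LC-MS, tested at 2 uM (on this read-out lower numbers stand for a shorter-lived compound and higher numbers for a longer-lived compound), compound 2 `Cn1ccc2ccc(-c3cc(Nc4cnccc4C(=O)NCc4cncnc4)cc4nccnc34)cc21` gives 0.4 h. Its only companion, compound 1 `CN(C)S(=O)(=O)c1ccccc1Nc1cc(-c2ccc3ccn(C)c3c2)c2nccnc2c1`, gives 0.233 h in this assay, a gap that stays inside the usual scatter, so the two compounds stand together rather than apart. Compound 3 `CC(=O)N1CC(CNC(=O)c2ccncc2Nc2cc(-c3ccc4ccn(C)c4c3)c3nccnc3c2)C1` has not yet been measured. It differs from compound 2 by 1-acetylazetidin-3-yl in place of pyrimidin-5-yl on a saturated chain carbon bound to an amide-type nitrogen. For the measured compounds named here, no measured pair differs in a single place, so there is no earlier step to lean on. The step is expected to be small, no change at the digits printed from compound 2 to compound 3 (within the scatter), with no direction beyond the scatter. Compound 3 is expected to give 0.4 h in this assay, within a range from 0.15 h to 1 h.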

Compound 3, half-life: > 1 h
Compound 3: a limit, no number; the forecaster's own chance of this, stated with the estimate: 5%; at least 2.5-fold (0.39 log units) between middle value and limit.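

In this assay, this position, on a saturated chain carbon bound to an amide-type nitrogen, proves responsive: 1-acetylazetidin-3-yl in place of pyrimidin-5-yl gives an at least 2.5-fold higher number from compound 2 to compound 3 (0.39 log units; beyond the scatter). Compound 1 and compound 2 differ in more than one place, so they showed nothing about this position. Compound 3 gives > 1 h, a limit and not a number, so the step has only a lower end: the limit of > 1 h in this assay, at which 1 of the 3 values shown sits.

The compounds shown leave open whether the acetyl group or the four-membered ring carries the change. A free azetidine amine or an open-chain acetamide at this place would separate the two.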